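Toward the Carboxy Analogue in a Cytotoxicity Read-Out

The compounds below may be only part of what the source reports. "The series", "measured", "known", "first", "only" and "open" are said of these compounds alone.

Values in an ADME assay on HEK293 cells (Homo sapiens) for cytotoxicity, with a stated time of 72 h (a higher number here means that more compound is needed for the effect, a lower number that less compound is needed), so far
Compound 1 `Cc1cc(NC(=O)Nc2ccc(F)cc2)c2ccccc2n1` gives > 25000 nM as a limit
Compound 2 `COC(=O)c1ccc(NC(=O)Nc2cc(C)nc3ccccc23)cc1` gives 15000 nM as a number
Compound 3 `Cc1cc(NC(=O)Nc2cnc3ccccc3c2)c2ccccc2n1` gives > 25000 nM as a limit

Within the data shown here, compound 2 holds the only true number here, since the other two values are limits. Compound 4 `Cc1cc(NC(=O)Nc2ccc(C(=O)O)cc2)c2ccccc2n1` differs from compound 2 by hydrogen in place of methyl on an oxygen next to a carbonyl group with hydrogen in place of methyl on an oxygen next to a carbonyl group, turning methoxycarbonyl into carboxy. Among the measured compounds shown here, the one measured step that bears on this is an at least 1.6-fold lower number from compound 1 to compound 2 (0.22 log units; that floor lies within the scatter) and it concerns the same position of change only loosely. Also relevant is the limit of > 25000 nM in this assay, at which 2 of the 3 values shown sit, as the ceiling of the read-out. No step beyond the scatter is therefore expected in this assay and any drift is expected toward a higher number. The expected change is a 1.5-fold higher number from compound 2 to compound 4 (0.17 log units; within the scatter) and no more. For compound 4 the estimate is 22000 nM with an expected range from 11000 nM to 35000 nM and a report as a limit would be no surprise.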

Compound 4, half-maximal effective concentration: > 25000 nM
Compound 4: only a limit was reported; the forecaster's own chance of this, stated with the estimate: 55%; middle value at least 1.1-fold (0.05 log units) from the limit.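

In this assay, turning methoxycarbonyl into carboxy gives an at least 1.6-fold higher number from compound 2 to compound 4 (0.22 log units; that floor lies within the scatter), so this change shows no step beyond the scatter, though the true size may be larger. Compound 4 gives > 25000 nM, which is a limit and not a number, and it joins the other compounds at that limit: the limit of > 25000 nM in this assay, at which 3 of the 4 values shown sit. The step from compound 1 to compound 4 cannot be read, as both values are limits.

As far as these compounds go, how far compound 4 lies past its limit stays open. So does whether ethoxycarbonyl or an amine in place of methoxycarbonyl would give a true number.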